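The source may report more compounds than this note shows. Statements on the series, on what has been measured and on what is new or still open speak of the compounds shown alone.

Measured compounds in an ADME assay on Huh7.5.1 cells (Homo sapiens) for cytotoxicity, read by ATP content, with a stated time of 48 h; a higher number here means that more compound is tolerated, a lower number that less compound is tolerated:
compound 1 `Cc1cc(C)c(-c2nc(CN3CCC(C(=O)NCCCN4C[C@H](C)C[C@H](C)C4)CC3)c(C)o2)c(C)c1`: 6570 nM
compound 2 `Cc1cccc(Cl)c1-c1nc(CN2CCC(C(=O)NCCCN3CCCC(C)C3)CC2)c(C)o1`: 16400 nM
compound 3 `Cc1cccc(Cl)c1-c1nc(CN2CCC(C(=O)NCCCN3CCC(C)(C)CC3)CC2)c(C)o1`: 11700 nM

Compound 1 gives the lowest number of the three. Its nearest neighbour is compound 3, whose value lies within the scatter of that of compound 1, while the value of compound 2 lies beyond it. Compounds 2 and 3 share the same aryl group and differ only in the amine; that step, a 1.4-fold lower number from compound 2 to compound 3 (0.15 log units; within the scatter), is within the scatter.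

Compound 4 `COc1cccc(C)c1-c1nc(CN2CCC(C(=O)NCCCN3C[C@H](C)C[C@H](C)C3)CC2)c(C)o1` is compound 1 with 2-methoxy-6-methylphenyl in place of 2,4,6-trimethylphenyl on an aromatic carbon. Among the compounds with values here, no measured pair differs at this aromatic carbon alone: compounds 2 and 3 carry another aryl group but also other amines, so their values show nothing that separates the aryl part from the amine part. Within the data shown here, the one measured step concerns the amine and was within the scatter. Nothing here points to a step beyond the scatter in this assay in either direction. Compound 4 is therefore expected to give about 7000 nM, with a range from 3000 nM to 16000 nM. The step of a 1.1-fold higher number from compound 1 to compound 4 (0.03 log units; within the scatter) implied by this estimate is expected to stay within the scatter.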

Compound 4, half-maximal cytotoxic concentration: 16700 nM
Compound 4: middle estimate off by 2.4-fold (0.38 log units), on the low side; measured number above the stated range.
By their numbers in this assay, from the lowest: compounds 1, 3, 2 and 4 (each within the scatter of the next, the first and the last beyond it).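

In this assay, within the data shown here, the aryl group on the aromatic carbon of the five-membered ring can shift the number with the amine unchanged: the step is a 2.5-fold higher number from compound 1 to compound 4 (0.41 log units; beyond the scatter), whereas the only earlier step, in the amine, stayed within the scatter. The entering 2-methoxy-6-methylphenyl has one hydrogen-bond acceptor and the leaving 2,4,6-trimethylphenyl has none, while both have the same heavy-atom count and the same aromatic ring of carbon only. No measurement shown accounts for the shift.

A comparison with 2,6-dimethylphenyl on the same amine would separate the effect of adding the methoxy group from that of losing a ring methyl. From the compounds shown here alone, it also remains open whether the step holds with the 3-methylpiperidin-1-yl or 4,4-dimethylpiperidin-1-yl amines of the other compounds.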